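Chloro series: bicyclic pyrazole in place of dimethylpyrazole

This account rests on a few compounds, and the source may have more. Where it says the series, first, only, none or still open, it means among the compounds named here.

Among the measured compounds shown here, compound 1 `CC(=O)N[C@@H]1CCC[C@H](C(=O)Nc2cc(-c3cnn(C)c3C)c(Cl)cn2)C1` is the lower of the two measured members of this pair on a physicochemical assay for lipophilicity, using the shake flask method, measured as octanol-water partition, at pH 7.4; on this read-out higher numbers stand for higher lipophilicity and lower numbers for lower lipophilicity; in this assay compound 1 gives 2.6. The other measured member, compound 2 `CC(=O)N[C@@H]1CCC[C@H](C(=O)Nc2cc(-c3cnn4c3CC(C)(C)C4)c(F)cn2)C1`, gives 3.3 in this assay, a value that lies above compound 1 by more than the scatter. For the measured compounds named here, compound 2 differs from compound 1 in two places at once, so no single step between them can be read off.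

Compound 3 `CC(=O)N[C@@H]1CCC[C@H](C(=O)Nc2cc(-c3cnn4c3CC(C)(C)C4)c(Cl)cn2)C1` is not yet measured in this assay. It keeps the chloro group of compound 1 and changes one place: a group of 10 heavy atoms (8 carbon, 2 nitrogen; one five-membered non-aromatic ring with 1 hetero atom, one five-membered aromatic ring with 2 hetero atoms) in place of a group of 7 heavy atoms (5 carbon, 2 nitrogen; one five-membered aromatic ring with 2 hetero atoms), on an aromatic carbon

The entering group carries the same ring system that compound 2 bears, and compound 2 already stands at 3.3 with a fluoro group in the place where compound 3 keeps a chloro group. On that basis compound 3 is expected to sit above compound 1, with an estimated step of a number 1.00 log units higher from compound 1 to compound 3 (beyond the scatter) in this assay, beyond the scatter. The estimate for compound 3 in this assay is 3.6, expected to fall between 3.1 and 4.1.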

Compound 3, distribution coefficient: 3.8
For compound 3 the middle estimate is 0.20 log units below the measured one, and the stated range covers the measured number.
By their numbers in this assay, from the lowest: compound 1; then compound 2; then compound 3.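

Among the compounds shown here, compound 3 gives the first one-place reading of the ring change: with the chloro group held, replacing 1,5-dimethyl-1H-pyrazol-4-yl on the aromatic carbon opposite the ring nitrogen gives a step of a number 1.20 log units higher from compound 1 to compound 3 (beyond the scatter) in this assay, and this step is large. For the compounds shown here, with the entering group held, the same series also gives a first reading at the halogen: chloro in place of fluoro gives a modest step of a number 0.50 log units higher from compound 2 to compound 3 (beyond the scatter) in this assay. Both places therefore move this read-out beyond the scatter when changed alone, but nothing in hand gives a reason for either step.

Whether chloro in place of fluoro gives a similar step with 1,5-dimethyl-1H-pyrazol-4-yl in place remains open, since the compounds shown read that halogen change only with the larger group present. Also open, as far as these compounds go, is how far the read-out would move with an amine or a hydroxyl group on the non-aromatic ring of the entering group, with the chloro group and the rest of the core of compound 3 held.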